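Extending the amine side chain in a diaryl ether series

This account rests on a few compounds, and the source may have more. Where it says the series, first, only, none or still open, it means among the compounds named here.

Measured compounds:
compound 1 `COc1cc(Oc2cccc(Nc3ccccc3)c2)cc(OC)c1CNCc1ccccc1` — 4070 nM
compound 2 `COc1cc(Oc2cccc(Nc3ccccc3)c2)cc(OC)c1CNCCNC(C)=O` — 18200 nM
compound 3 `COc1cc(Oc2cccc(Nc3ccccc3)c2)cc(OC)c1CNCc1ccc(C)cc1` — 13800 nM

All three share one core and differ only in the group on the saturated chain carbon bound to the amine nitrogen. In a functional assay on HCT-116 cells (Homo sapiens) for inhibition, read by MTT assay, with a stated time of 72 h (on this read-out lower numbers stand for stronger inhibition and higher numbers for weaker inhibition), compound 3 gives 13800 nM, the second highest of the three numbers; one of its two steps lies within the scatter (a 1.3-fold lower number from compound 2 to compound 3 (0.12 log units; within the scatter)) and the other lies well beyond it (a 3.4-fold higher number from compound 1 to compound 3 (0.53 log units; beyond the scatter)).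

Compound 4 `COc1ccc(CCCNCc2c(OC)cc(Oc3cccc(Nc4ccccc4)c3)cc2OC)cc1` carries the change (2-(4-methoxyphenyl)ethyl in place of 4-methylphenyl on a saturated chain carbon bound to an amine nitrogen). Going by the values given here, none of the measured steps makes this exact change. The nearest comparison is the step from compound 1 to compound 3 (a 3.4-fold higher number from compound 1 to compound 3 (0.53 log units; beyond the scatter)), where a 4-methylphenyl in place of phenyl raised the number; and the step from compound 2 to compound 3 (a 1.3-fold lower number from compound 2 to compound 3 (0.12 log units; within the scatter)), where an acetamidomethyl and a 4-methylphenyl gave numbers within the scatter. Neither covers a 2-(4-methoxyphenyl)ethyl group, so no strong shift in either direction is expected.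

Compound 4 is therefore estimated at 10000 nM, within 3000 nM to 35000 nM, a step of a 1.4-fold lower number from compound 3 to compound 4 (0.14 log units; within the scatter) that is expected to stay near compound 3.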

Compound 4, half-maximal inhibitory concentration: 2850 nM
The estimate for compound 4 lay 3.5-fold (0.55 log units) above the measured number; measured number outside the range, below it.
By their numbers in this assay, from the lowest: compounds 4 and 1 (each within the scatter of the next); then compounds 3 and 2 (each within the scatter of the next).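

In this assay the position on the saturated chain carbon bound to an amine nitrogen accepts the 2-(4-methoxyphenyl)ethyl group with a clear recovery, shown by a 4.8-fold lower number from compound 3 to compound 4 (0.69 log units; beyond the scatter) and by a 6.4-fold lower number from compound 2 to compound 4 (0.81 log units; beyond the scatter), while a 1.4-fold lower number from compound 1 to compound 4 (0.15 log units; within the scatter) stays within the scatter. An aromatic ring on this side chain therefore does not set the number by itself: compound 1, compound 3 and compound 4 each carry one six-membered aromatic ring of carbon only, yet compound 3 stands apart from compound 4 and lies within the scatter of compound 2, which has no such ring on its side chain. Nothing available accounts for the difference between the 4-methylphenyl and 2-(4-methoxyphenyl)ethyl groups.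

The compounds shown do not separate the methoxy group from the ethyl link, as compound 4 alters both at once relative to compound 3. They also leave open how a 3-phenylpropyl group, with the ring but no methoxy, or a 4-methoxybenzyl group on the amine, with the methoxy on a shorter chain, would read, and whether a carboxylic acid at the end of the chain would be tolerated.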